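The source may report more compounds than this note shows. Statements on the series, on what has been measured and on what is new or still open speak of the compounds shown alone.

Measured in a functional assay on MCF7 cells (Homo sapiens) for cytotoxicity, read by neutral red uptake, with a stated time of 3 days; a lower number here means a stronger inhibitor, a higher number a weaker inhibitor:
- compound 1 `Cc1c(F)c(N)c2c(=O)cc(-c3ccc(N)c(F)c3)oc2c1F`: 13 nM
- compound 2 `Nc1ccc(-c2cc(=O)c3c(N)c(F)c(Br)c(F)c3o2)cc1F`: 160 nM
- compound 3 `[N-]=[N+]=Nc1c(F)c(N)c2c(=O)cc(-c3ccc(N)c(F)c3)oc2c1F`: 460 nM

Compound 3 has the highest number of the three, which makes it the weakest inhibitor in this small set. Compound 4 `CCOC(=O)c1c(F)c(N)c2c(=O)cc(-c3ccc(N)c(F)c3)oc2c1F` keeps the shared core and changes one group, with ethoxycarbonyl in place of azido on an aromatic carbon. All three measured steps concern this same carbon. Bromo in place of methyl gave a large step, a 12-fold higher number from compound 1 to compound 2 (1.09 log units; beyond the scatter). Azido in place of methyl gave a larger one, a 35-fold higher number from compound 1 to compound 3 (1.55 log units; beyond the scatter). Azido in place of bromo gave a modest one, a 2.9-fold higher number from compound 2 to compound 3 (0.46 log units; beyond the scatter). Within the data shown here, no measured compound carries ethoxycarbonyl, so the data cannot fix the size of the next step with any confidence. Both replacements of methyl raised the number, so a modest further rise in this assay is the expectation, not a return towards compound 1. The estimated step is a 2.2-fold higher number from compound 3 to compound 4 (0.34 log units; beyond the scatter). Compound 4 is estimated at 1000 nM, with an expected range from 200 nM to 5000 nM.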

Compound 4, half-maximal inhibitory concentration: 1400 nM
Estimate against measurement, compound 4: 1.4-fold (0.15 log units) below, within the range that was stated.
By their numbers in this assay, from the lowest: compound 1; then compound 2; then compound 3; then compound 4.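

In this assay, among these compounds, ethoxycarbonyl at this aromatic carbon gives the highest number so far, with a 3.0-fold higher number from compound 3 to compound 4 (0.48 log units; beyond the scatter), an 8.8-fold higher number from compound 2 to compound 4 (0.94 log units; beyond the scatter) and a 110-fold higher number from compound 1 to compound 4 (2.03 log units; beyond the scatter). Three different replacements of methyl, namely bromo, azido and ethoxycarbonyl, have now all raised the number, and the step from methyl to ethoxycarbonyl is the largest of them, so among these four compounds methyl stands alone at the low end. No measurement shown here explains why the number changes with the group at this carbon.

The compounds shown leave open whether the low number belongs to methyl alone or would also come with ethyl or chloro at this carbon, and whether a carboxylic acid or an amide there would track with ethoxycarbonyl. As far as these compounds go, all four compounds differ only at this one carbon, so changes elsewhere on the shared core remain unexplored here.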